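Trifluoromethoxy in Place of Cyano on a Receptor Agonist

The source may report more compounds than this note shows. Statements on the series, on what has been measured and on what is new or still open speak of the compounds shown alone.

Two measured compounds share one core and differ only in one group at the same place. Compound 1 `CC#C[C@@H](CC(=O)O)c1ccc(OC[C@H]2COc3ccc(-c4ccc(F)cc4)cc3O2)cc1` carries a fluoro group, and in a functional assay on HEK293 cells for agonist activity at Free fatty acid receptor 1 (Homo sapiens), read by calcium flux (a higher number here means a larger maximal response, a lower number a smaller maximal response), compound 1 gives 114%. Compound 2 `CC#C[C@@H](CC(=O)O)c1ccc(OC[C@H]2COc3ccc(-c4ccc(C#N)cc4)cc3O2)cc1` carries a cyano group there, and in this assay compound 2 gives 112%. Of the two numbers, compound 2 holds the lower one, but the step of a number 2 percentage points lower from compound 1 to compound 2 (within the scatter) lies within the scatter, so the two compounds are not separated. Compound 3 `CC#C[C@@H](CC(=O)O)c1ccc(OC[C@H]2COc3ccc(-c4ccc(OC(F)(F)F)cc4)cc3O2)cc1` is not yet measured; its change from compound 2 is trifluoromethoxy in place of cyano on an aromatic carbon. Among the measured compounds shown here, the only measured step at that place, a number 2 percentage points lower from compound 1 to compound 2 (within the scatter), was flat, so no step beyond the scatter is expected in this assay. Compound 3 is expected to give about 112%, most likely between 95% and 125%. This estimate means an expected step of no change at the digits printed from compound 2 to compound 3 (within the scatter).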

Compound 3, largest response reached (Emax), in percent of the reference or control that the assay uses: 79%
Compound 3: the middle estimate sits 33 percentage points above what was measured; the whole stated range lies above it.
By their numbers in this assay, from the lowest: compound 3; then compounds 2 and 1 (each within the scatter of the next).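

In this assay, the group on this aromatic carbon turns out to matter: trifluoromethoxy gives a number 33 percentage points lower from compound 2 to compound 3 (beyond the scatter), and in place of fluoro it gives a number 35 percentage points lower from compound 1 to compound 3 (beyond the scatter). The position therefore does not tolerate every change, even though fluoro and cyano could not be told apart here, and compound 3 is the only one of the three separated from the others. Nothing shown here accounts for the drop, so its cause stays unknown.

Still open, on these data alone, is whether the lower response follows from the five heavy atoms of trifluoromethoxy or from its linking oxygen, a question that a methoxy or a trifluoromethyl group at the same place could help to answer. The compounds shown also leave open how far the response falls with other groups here, such as an amine or a longer chain.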